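A few compounds are considered here, and "the series" means these few. Any claim that something is new, unique, unknown or untested is made for them only; others in the source may bear on it.

Going by the values given here, compound 1 `OCCNc1nnc2nncn2n1` gives 45300 nM in a functional assay on HL-60 cells (Homo sapiens) for inhibition, read by MTT assay, with a stated time of 72 h (a lower number here means a stronger inhibitor, a higher number a weaker inhibitor), the highest of the three numbers measured so far. The nearest is compound 3 `CCCC(=O)N1CCN(c2nnc3nncn3n2)CC1`, which in this assay gives 9840 nM; the furthest is compound 2 `CN(C)c1nnc2nncn2n1`, which in this assay gives 4840 nM. Among the compounds with values here, the one measured step from compound 1 is a 9.4-fold lower number from compound 1 to compound 2 (0.97 log units; beyond the scatter), where dimethylamino replaces (2-hydroxyethyl)amino on an aromatic carbon.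

The next compound, compound 4 `c1nnc2nnc(NC3CCCC3)nn12`, differs from compound 1 as follows: cyclopentyl in place of 2-hydroxyethyl on a nitrogen on an aromatic ring. Within the data shown here, no measured pair covers this exact exchange; the step that bears on it is the one from compound 1 to compound 2, since both changes remove the 2-hydroxyethyl group from the shared core, and that step was modest yet beyond the scatter. A lower number in this assay is therefore expected for compound 4, though of uncertain size given a single related step.

Compound 4 is expected to give about 9000 nM in this assay, within 2500 nM to 30000 nM. The expected step is a 5.0-fold lower number from compound 1 to compound 4 (0.70 log units; beyond the scatter).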

Compound 4, half-maximal inhibitory concentration: 38200 nM
Compound 4: middle estimate off by 4.2-fold (0.63 log units), on the low side; the whole stated range lies below it.
By their numbers in this assay, from the lowest: compound 2; then compound 3; then compounds 4 and 1 (each within the scatter of the next).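

In this assay, exchanging 2-hydroxyethyl for cyclopentyl on this nitrogen leaves the read-out unchanged: a 1.2-fold lower number from compound 1 to compound 4 (0.07 log units; within the scatter). Removing 2-hydroxyethyl, with its hydrogen-bond donor and acceptor, therefore does not by itself go with a change in this series, whereas a 9.4-fold lower number from compound 1 to compound 2 (0.97 log units; beyond the scatter) comes with dimethylamino replacing the whole (2-hydroxyethyl)amino group. Nothing measured on these compounds accounts for the difference between these two steps.

Still open, as far as these compounds go, is whether the step to compound 2 belongs to dimethylamino itself or to any fully substituted amine on the aromatic carbon, which a comparison with morpholine or diethylamino at that carbon would help to settle. Also open, from the compounds shown here alone, is how a single small methyl group, a longer butyl chain or a carboxylic acid on this nitrogen would read out.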